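Amide chain shortening on two sulfonate ester cores

The source may hold more compounds than are shown below. What is called first, only, known or untested is meant among the compounds shown, and "the series" means these compounds.

Compound 1 `CCCCCC(=O)Nc1cccc(S(=O)(=O)Oc2ccccc2C(C)C)c1` and compound 2 `CC(C)C(=O)Nc1cccc(S(=O)(=O)Oc2ccccc2C(C)C)c1` share one core; compound 3 `CCCCCC(=O)Nc1ccc(S(=O)(=O)Oc2ccccc2C(C)C)cc1` and compound 4 `CC(C)C(=O)Nc1ccc(S(=O)(=O)Oc2ccccc2C(C)C)cc1` share the other. The difference between the two cores is not broken down here. In a functional assay on HT-29 cells (Homo sapiens) for antiproliferative activity, read by sulforhodamine B assay, with a stated time of 48 h (on this read-out higher numbers stand for weaker inhibition and lower numbers for stronger inhibition), compound 1 gives 19000 nM and compound 2 gives 16000 nM. The change between them is isopropyl in place of pentyl on a carbonyl carbon and it gave a 1.2-fold lower number from compound 1 to compound 2 (0.07 log units; within the scatter). In this assay compound 3 gives 6400 nM, the lowest of the three numbers, with the gap to compound 2 and to compound 1 both beyond the scatter. Compound 4 has not yet been measured in this assay. It differs from compound 3 by isopropyl in place of pentyl on a carbonyl carbon, the same change as from compound 1 to compound 2, at a place described in the same words. The expected step is estimated as a 1.2-fold lower number from compound 3 to compound 4 (0.07 log units; within the scatter), resting on a 1.2-fold lower number from compound 1 to compound 2 (0.07 log units; within the scatter) and on the place of the change being unchanged. Compound 4 is therefore expected near 5500 nM, with the likely range estimated from 2500 nM to 13000 nM.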

Compound 4, half-maximal inhibitory concentration: 14000 nM
The estimate for compound 4 lay 2.5-fold (0.41 log units) below the measured number; the measured number lies above the stated range.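

In this assay, isopropyl in place of pentyl on a carbonyl carbon gives a 2.2-fold higher number from compound 3 to compound 4 (0.34 log units; beyond the scatter), whereas the same change on the other core gives a 1.2-fold lower number from compound 1 to compound 2 (0.07 log units; within the scatter). Set side by side, the two steps cannot be told apart, so these pairs give no firm sign that the core alters the effect of the change: the same change on two cores in this assay, a 1.2-fold lower number (0.07 log units; within the scatter) from compound 1 to compound 2 and a 2.2-fold higher number (0.34 log units; beyond the scatter) from compound 3 to compound 4, 2.6-fold (0.41 log units) apart, within the scatter of two such steps. Among the compounds shown here, equally, they do not show that the change carries over unaltered: only two pairs are at hand, and only the step on the core of compound 3 lies beyond the scatter.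

Still open, as far as these compounds go, is whether chain length or branching counts for more, as pentyl and isopropyl differ in both, and a straight propyl chain or a tert-butyl group on the same carbonyl carbon, on both cores, would separate the two. Also open, from the compounds shown here alone, is how a terminal amine or carboxylic acid on the chain would read in this assay.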